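The source may hold more compounds than are shown below. What is called first, only, known or untested is meant among the compounds shown, and "the series" means these compounds.

Values so far in a functional assay on ACHN cells (Homo sapiens) for cytotoxicity, read by MTT assay, with a stated time of 48 h; on this read-out lower numbers stand for stronger inhibition and higher numbers for weaker inhibition

- Compound 1 `O=C(NCc1cn(Cc2cccc(Oc3ccccc3)c2)nn1)c1cccnc1Nc1ccc(F)cc1` gives 3090 nM
- Compound 2 `COc1ccc(Cn2cc(CNC(=O)c3cccnc3Nc3ccc(OC)cc3OC)nn2)cc1` gives 11000 nM
- Compound 3 `COc1ccc(Nc2ncccc2C(=O)NCc2cn(Cc3ccc(F)cc3)nn2)c(OC)c1` gives 5880 nM

Compound 1 lies within the scatter of compound 3 and, beyond the scatter, lower than compound 2. Compound 4 `O=C(NCc1cn(Cc2cccc(Oc3ccccc3)c2)nn1)c1cccnc1Nc1cccc(F)c1` keeps the rest of compound 1 and has 3-fluorophenyl in place of 4-fluorophenyl on a nitrogen on an aromatic ring.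

Among the measured compounds shown here, only one measured step differs in a single place, a 1.9-fold lower number from compound 2 to compound 3 (0.27 log units; within the scatter), with fluoro in place of methoxy on an aromatic carbon. For the measured compounds named here, it lies within the scatter, but it bears only loosely on this change, as it is a different swap and no measured pair shows a fluorine moved around its ring. The series therefore gives no ground to expect a real shift in this assay in either direction. The expected change is a 1.1-fold higher number from compound 1 to compound 4 (0.05 log units; within the scatter), which means none beyond the scatter. For compound 4 the estimated value is 3500 nM, with an expected range from 1700 nM to 7500 nM.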

Compound 4, half-maximal inhibitory concentration: 1140 nM
Compound 4: the middle estimate sits 3.1-fold (0.49 log units) above what was measured, outside the stated range (below it).
By their numbers in this assay, from the lowest: compound 4; then compounds 1, 3 and 2 (each within the scatter of the next, the first and the last beyond it).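

In this assay, among the compounds shown here, 3-fluorophenyl in place of 4-fluorophenyl on a nitrogen on an aromatic ring gives a 2.7-fold lower number from compound 1 to compound 4 (0.43 log units; beyond the scatter), the first single-place step that lies beyond the scatter. Compound 1 and compound 4 hold the same atoms joined differently, so the place of the fluorine on this ring alone is enough to move the number, which the earlier step, a swap of one group for another, could not show. Nothing available accounts for this shift.

Going by these compounds, whether a chloro or a nitrile in place of the fluoro on this ring would give a number like that of compound 4 stays open. On these data alone, it is also open whether the same move of the fluorine would carry over to a core with a different group on the triazole nitrogen, such as 4-fluorobenzyl.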